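Aminothiazole series: piperidinylmethyl extension of compound 1

This account rests on a few compounds, and the source may have more. Where it says the series, first, only, none or still open, it means among the compounds named here.

Measured compounds:
compound 1, `Cc1cccc(Nc2nc(-c3ccncc3)c(C)s2)c1`, 10000 nM
compound 2, `Oc1cccc(Nc2nc(-c3ccncc3)cs2)c1`, 28800 nM
compound 3, `Cc1sc(Nc2ccc3c(c2)CCC3)nc1-c1ccncc1`, 12000 nM

In a functional assay on RCC4 cells (Homo sapiens) for inhibition, read by XTT assay, with a stated time of 4 days (on this read-out higher numbers stand for weaker inhibition and lower numbers for stronger inhibition), compound 1 gives 10000 nM, the lowest of the three numbers. Compound 3 sits within the scatter of compound 1, so no order between them can be read. Compound 2 gives 28800 nM, a number beyond the scatter from compound 1. No pair of these compounds differs in a single place, so no measured step is available on the shared core.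

Compound 4, `Cc1cccc(Nc2nc(-c3ccncc3)c(CN3CCCCC3)s2)c1`, has not yet been measured in this assay. It differs from compound 1 by piperidin-1-yl in place of hydrogen on a saturated chain carbon bound to an aromatic carbon. The measured compounds give no guide to a change of this kind, and none of them carries a saturated ring. The step of a 1.7-fold lower number from compound 1 to compound 4 (0.22 log units; within the scatter) is therefore expected to be modest, probably toward a lower number but not certainly beyond the scatter. Compound 4 is estimated at 6000 nM, with a range from 1500 nM to 25000 nM.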

Compound 4, half-maximal inhibitory concentration: 13200 nM
Beside the measured number, compound 4's estimate is 2.2-fold (0.34 log units) below it, and the stated range covers the measured number.
By their numbers in this assay, from the lowest: compounds 1, 3 and 4 (each within the scatter of the next); then compound 2.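

In this assay, among these compounds, the first step on the shared core that differs in one place is a 1.3-fold higher number from compound 1 to compound 4 (0.12 log units; within the scatter), so the change from methyl to (piperidin-1-yl)methyl gives no readable change in the number. On the saturated chain carbon bound to an aromatic carbon, the added six-membered non-aromatic ring with its hydrogen-bond acceptor is therefore accommodated in this read-out, without any gain that can be read. The data give no measured reason for this flat step.

Going by these compounds, it remains open whether morpholin-4-yl, diethylamino or a carboxylic acid on the same saturated chain carbon would also stay within the scatter or would move the number beyond it. Also open, on these data alone, is whether a longer chain carrying the piperidin-1-yl would give a step beyond the scatter in either direction.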